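Bromo for methyl on the core of compound 2

A few compounds are considered here, and "the series" means these few. Any claim that something is new, unique, unknown or untested is made for them only; others in the source may bear on it.

Values in a functional assay on PC-3 cells (Homo sapiens) for cytotoxicity, read by colorimetric assay; on this read-out lower numbers stand for stronger inhibition and higher numbers for weaker inhibition:
- compound 1 `O=C(/C=C/c1ccc(CN2C(=O)/C(=C3\Nc4ccccc4\C3=N/O)c3cccc(Cl)c32)cc1)NO`: 90 nM
- compound 2 `Cc1ccc2c(c1)/C(=C1/Nc3ccccc3/C1=N\O)C(=O)N2Cc1ccc(/C=C/C(=O)NO)cc1`: 60 nM
- compound 3 `Cc1ccc2c(c1)/C(=C1/Nc3ccccc3/C1=N\O)C(=O)N2Cc1ccc(C(=O)NO)cc1`: 90 nM

All three values lie within the scatter of one another, so compound 2 at 60 nM stands apart from neither neighbour. Compound 4 `O=C(/C=C/c1ccc(CN2C(=O)/C(=C3\Nc4ccccc4\C3=N/O)c3cc(Br)ccc32)cc1)NO` carries bromo in place of methyl on an aromatic carbon. For the measured compounds named here, no measured step covers this exchange. The only one, a 1.5-fold higher number from compound 2 to compound 3 (0.18 log units; within the scatter), concerns the hydroxamic side chain and not this position. Compound 1, with chloro on the core, gives 90 nM. No step beyond the scatter is therefore expected in this assay. The expected change is a 1.2-fold higher number from compound 2 to compound 4 (0.07 log units; within the scatter). Compound 4 is estimated at 70 nM, with an expected range of 30 nM to 160 nM.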

Compound 4, half-maximal inhibitory concentration: 90 nM
The estimate for compound 4 lay 1.3-fold (0.11 log units) below the measured number, and the stated range covers the measured number.
By their numbers in this assay, from the lowest: compounds 2, 1, 3 and 4 (each within the scatter of the next).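

In this assay, for the compounds shown here, the only measured step at this position of the core is a 1.5-fold higher number from compound 2 to compound 4 (0.18 log units; within the scatter), so methyl and bromo on this aromatic carbon are not separated by this read-out. The exchange keeps the heavy-atom count and adds no hydrogen-bond donor or acceptor, and the step shows that a halogen here leaves the number within the scatter of compound 2. Nothing available explains why the two groups read alike.

As far as these compounds go, whether an amine or a carboxylic acid at this position would give a step beyond the scatter remains open. Also open, from the compounds shown here alone, is whether bromo for methyl reads the same with the hydroxycarbamoyl side chain of compound 3.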